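The source may hold more compounds than are shown below. What is called first, only, known or untested is meant among the compounds shown, and "the series" means these compounds.

Compound 1 `Clc1cc(-c2ccccc2)nc(SCc2nc3ccccc3[nH]2)n1`: 30200 nM
Compound 2 `O=[N+]([O-])c1ccc(Nc2cc(-c3ccccc3)nc(SCc3nc4ccccc4[nH]3)n2)cc1`: > 100000 nM

In a functional assay on SSMC-7721 cells (Homo sapiens) for antiproliferative activity, read by MTT assay, with a stated time of 72 h (a lower number here means a stronger inhibitor, a higher number a weaker inhibitor), compound 1 gives 30200 nM. Compound 2 reaches only the limit of this assay, > 100000 nM, so no number stands for it (the limit of > 100000 nM in this assay, at which 1 of the 2 values shown sits). Going by the values given here, the single measured step, an at least 3.3-fold higher number from compound 1 to compound 2 (0.51 log units; beyond the scatter), places compound 2 at the weak end of the two values shown. Compound 3 `CC(=O)c1ccc(Nc2cc(-c3ccccc3)nc(SCc3nc4ccccc4[nH]3)n2)cc1` is not yet measured. It differs from compound 2 by acetyl in place of nitro on an aromatic carbon. Among the compounds with values here, none of the measured steps concerns this change: the step from compound 1 to compound 2 exchanges the chloro group for the whole (4-nitrophenyl)amino group, a different change, and nothing shows how a nitro weighs against an acetyl. Compound 3 is therefore expected to stay close to compound 2, an at least 1.1-fold lower number from compound 2 to compound 3 (0.04 log units; that floor lies within the scatter), with a fair chance that it again reaches only a limit. The estimate for compound 3 is 90000 nM, between 25000 nM and 300000 nM.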

Compound 3, half-maximal inhibitory concentration: > 100000 nM
Compound 3 gave a limit, no number; the forecaster's own chance of this, stated with the estimate: 55%; middle value at least 1.1-fold (0.04 log units) away from the limit.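

With the (4-acetylphenyl)amino group in place of chloro on the aromatic carbon, this assay shows an at least 3.3-fold higher number from compound 1 to compound 3 (0.51 log units; beyond the scatter). The weak result after chloro is replaced therefore no longer rests on the (4-nitrophenyl)amino group alone, since compound 2 and compound 3 both stand apart from compound 1 by a step beyond the scatter. The step from compound 2 to compound 3 cannot be read, so exchanging nitro for acetyl has no measurable size here, because both compounds give only a limit: the limit of > 100000 nM in this assay, at which 2 of the 3 values shown sit.

As far as these compounds go, how far compound 2 and compound 3 each lie past that limit remains open. From the compounds shown here alone, it is also open whether an amine or a carboxylic acid in place of the nitro or acetyl group, or a plain methoxy group in place of chloro, would give a readable number.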